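The source may report more compounds than this note shows. Statements on the series, on what has been measured and on what is new or still open speak of the compounds shown alone.

Measured so far:
compound 1 `C=C(C)C(=O)Nc1cccc(-c2nc3ccccc3s2)c1`: > 25000 nM
compound 2 `CN(C)CCC(=O)Nc1cccc(-c2nc3ccccc3s2)c1`: > 25000 nM

In an ADME assay on HEK293 cells (Homo sapiens) for inhibition, with a stated time of 72 h (on this read-out higher numbers stand for an effect only at larger amounts of compound and lower numbers for an effect already at smaller amounts), compound 1 reaches only the limit > 25000 nM. Compound 2 in this assay likewise shows only the limit > 25000 nM. The step from compound 1 to compound 2 is a step that the two limits leave unreadable from compound 1 to compound 2. Both values sit at the limit of > 25000 nM in this assay, at which 2 of the 2 values shown sit, so compound 2 stands at the limit with no readable position within the series.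

Compound 3 `O=C(Nc1cccc(-c2nc3ccccc3s2)c1)c1cccnc1Cl` differs from compound 2 by 2-chloropyridin-3-yl in place of 2-(dimethylamino)ethyl on a carbonyl carbon. Within the data shown here, the single measured step bears on this change only in that it is unreadable; its size is unknown, so no direction can be drawn from it. Compound 3 is expected to give about 30000 nM in this assay, within 8000 nM to 120000 nM, most probably again reported as a limit. The estimated step is a step that the limit leaves unreadable from compound 2 to compound 3.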

Compound 3, half-maximal effective concentration: > 25000 nM
Compound 3: no number, only a limit; the forecaster's own chance of this, stated with the estimate: 75%; the middle value lies beyond the limit too.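

Compound 3, like compound 1 and compound 2, gives only a limit in this assay, so no step among the three can be read: the limit of > 25000 nM in this assay, at which 3 of the 3 values shown sit.

The compounds shown leave open how the groups on the carbonyl carbon compare in this assay.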